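Fluoro to iodo on an inactive sulfonate ester

The source may hold more compounds than are shown below. What is called first, only, known or untested is meant among the compounds shown, and "the series" means these compounds.

In a functional assay on HT-29 cells (Homo sapiens) for antiproliferative activity, read by sulforhodamine B assay, with a stated time of 48 h (a higher number here means a weaker inhibitor, a lower number a stronger inhibitor), compound 3 (`CCN1CCN(c2ccc(S(=O)(=O)Oc3cccc(F)c3)cc2)C1=O`) gives > 100000 nM, which is a limit of the assay and not a number. Compound 2 (`CCN1CCN(c2ccc(S(=O)(=O)Oc3ccccc3OC)cc2)C1=O`) also stands at a limit, > 100000 nM. Together these two make up the evidence so far at the weak end, (the limit of > 100000 nM in this assay, at which 2 of the 3 values shown sit).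

The next step leads to compound 4 (`CCN1CCN(c2ccc(S(=O)(=O)Oc3cccc(I)c3)cc2)C1=O`) and is iodo in place of fluoro on an aromatic carbon. It places iodo in place of fluoro on an aromatic carbon, meta to a large group, so that 3-fluorophenyl becomes 3-iodophenyl.

Among the compounds with values here, the only measured step is a step that the two limits leave unreadable from compound 2 to compound 3, and it offers no size to carry over. The better guide is compound 1 (`CN1CCN(c2ccc(S(=O)(=O)Oc3cccc(I)c3)cc2)C1=O`), which already holds the 3-iodophenyl group and differs from compound 4 elsewhere in the molecule. The 3-fluorophenyl compound 3 reaches only a limit. In this assay compound 1 gives 590 nM. On the strength of that value, a large move towards stronger inhibition is expected, estimated as an at least 120-fold lower number from compound 3 to compound 4 (2.09 log units; beyond the scatter). The uncertainty stays wide, as this rests on a single iodo compound, and compound 4 could still fall to the limit. For compound 4 the expected value is 800 nM, with an estimated range of 150 nM to 6000 nM.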

Compound 4, half-maximal inhibitory concentration: 3100 nM
The estimate for compound 4 lay 3.9-fold (0.59 log units) below the measured number; the measured number falls inside the stated range.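

In this assay, within the data shown here, iodo in place of fluoro on this aromatic carbon gives an at least 32-fold lower number from compound 3 to compound 4 (1.50 log units; beyond the scatter), which shows that activity at this position depends on the group placed there, even on a core that had so far given only limits; the true size of the step stays unknown, as its starting point is a limit of the assay and not a number: the limit of > 100000 nM in this assay, at which 2 of the 4 values shown sit. Exchanging the 2-methoxyphenyl group for 3-iodophenyl gives an at least 32-fold lower number from compound 2 to compound 4 (1.50 log units; beyond the scatter), although this step changes both the group and its place on the ring, so the two cannot be separated. The 3-iodophenyl group also keeps a measurable number across a second change, since methyl in place of hydrogen on the saturated chain carbon gives a 5.3-fold higher number from compound 1 to compound 4 (0.72 log units; beyond the scatter), a modest loss that still leaves a value well clear of the limit.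

The compounds shown leave open whether chloro or bromo at the same place would also give a measurable number, as only fluoro and iodo can be compared here. They also leave open whether a longer chain on the ring nitrogen would weaken the iodo compounds further.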